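This account rests on a few compounds, and the source may have more. Where it says the series, first, only, none or still open, it means among the compounds named here.

Compound 1 `CC1=C(C(=O)OCc2ccccn2)C(c2ccc(Br)cc2)C2=C(CCCC2=O)N1`: 2.42
Compound 2 `CC1=C(C(=O)OCc2ccccn2)C(c2ccc(Cl)cc2)C2=C(CCCC2=O)N1`: 2.24
Compound 3 `CC1=C(C(=O)OCc2cccnc2)C(c2ccc(C#N)cc2)C2=C(CCCC2=O)N1`: 1.36

Of the compounds shown here, three sharing one core have been measured in a physicochemical assay for lipophilicity, measured as octanol-water partition; on this read-out lower numbers stand for lower lipophilicity and higher numbers for higher lipophilicity. In this assay, within the data shown here, compound 1 gives 2.42 and compound 2 gives 2.24; the only single-point step among them, a number 0.18 log units lower from compound 1 to compound 2 (within the scatter), is a chloro in place of bromo on an aromatic carbon. Compound 3 gives 1.36 and stands lowest of the three, its gap to compound 2 and to compound 1 both lying beyond the scatter; compound 3 differs from each of them in more than one place, so those gaps are read only as what the two values show.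

Compound 4 `CC1=C(C(=O)OCc2cccnc2)C(c2ccco2)C2=C(CCCC2=O)N1` is the next compound, and it differs from compound 3 as follows: furan-2-yl in place of 4-cyanophenyl on a saturated ring carbon. Among the measured compounds shown here, no measured step changes the group on this saturated ring carbon, and the one step known, from compound 1 to compound 2, is a halogen swap within the scatter, so it offers no direct guide. The change is therefore expected to give a modest downward step, a number 0.16 log units lower from compound 3 to compound 4 (within the scatter). Compound 4 is estimated at 1.2, within a range from 0.7 to 1.7.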

Compound 4, partition coefficient: 1.03
Beside the measured number, compound 4's estimate is 0.17 log units above it; measured number inside the range.
By their numbers in this assay, from the lowest: compound 4; then compound 3; then compounds 2 and 1 (each within the scatter of the next).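

Among these compounds, with furan-2-yl in place of 4-cyanophenyl on the saturated ring carbon, this assay shows a number 0.33 log units lower from compound 3 to compound 4 (beyond the scatter) and so gives the first single-place step here that lies beyond the scatter, whereas the chloro in place of bromo step on an aromatic carbon stayed within it. The step is modest, but it shows that this position can move the number even when the count of hydrogen-bond acceptors in the group stays the same. No evidence at hand accounts for the size or direction of this step.

The change replaces the six-membered aromatic ring and removes the nitrile in one move, so the compounds shown cannot separate the two. Going by these compounds, a plain phenyl on this carbon would tell them apart, and whether the step carries over to the ((pyridin-2-yl)methoxy)carbonyl compounds also remains open.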